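This account rests on a few compounds, and the source may have more. Where it says the series, first, only, none or still open, it means among the compounds named here.

Measured in an ADME assay for permeability, using PAMPA, at pH 7.4; a higher number here means that the compound crosses the layer faster, a lower number that the compound crosses the layer more slowly:
Compound 1 `CN(C[C@H]1Cc2c(cccc2N2CCN(C3COC3)CC2)CN1)[C@H]1CCCc2cccnc21`: 725 nm/s
Compound 2 `CN(C[C@H]1Cc2c(cccc2N2CCN3CCC[C@H]3C2)CN1)[C@H]1CCCc2cccnc21`: 167 nm/s

In this assay, compound 2 gives 167 nm/s, the lower of the two numbers. Compound 3 `CN(C[C@H]1Cc2c(cccc2N2CCN3CCC[C@@H]3C2)CN1)[C@H]1CCCc2cccnc21` departs from it in one way: the two compounds have the same atoms and bonds and differ only in configuration as drawn: 1 of 3 stereo elements differ; a stereocentre at a saturated ring carbon is drawn S in compound 2 and R in compound 3. Going by the values given here, the only measured step is a 4.3-fold lower number from compound 1 to compound 2 (0.64 log units; beyond the scatter). Among the compounds with values here, that step exchanges one group for another, so it bears only indirectly, and no measured pair tests a change of configuration alone. No shift beyond the scatter is therefore expected. The estimated step is a 1.1-fold higher number from compound 2 to compound 3 (0.03 log units; within the scatter). Compound 3 is expected at 180 nm/s, within an estimated range of 90 nm/s to 360 nm/s.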

Compound 3, apparent permeability: 740 nm/s
For compound 3 the middle estimate is 4.1-fold (0.61 log units) below the measured one; measured number above the stated range.
By their numbers in this assay, from the lowest: compound 2; then compounds 1 and 3 (each within the scatter of the next).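

In this assay, the stereocentre at this saturated ring carbon matters, with a 4.4-fold higher number from compound 2 to compound 3 (0.65 log units; beyond the scatter), and this step can be assigned to configuration alone because nothing else changes: the fact that compounds 2 and 3 differ only in the configuration as drawn. The earlier drop on exchanging the group on the aromatic carbon therefore holds only for the S form: with the R form, the same exchange gives a 1.0-fold higher number from compound 1 to compound 3 (0.01 log units; within the scatter).

From the compounds shown here alone, it remains open whether the other stereocentres show a similar split, and whether a piperidine ring in place of the five-membered ring would keep the gap between S and R.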